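The compounds below may be only part of what the source reports. "The series", "measured", "known", "first", "only" and "open" are said of these compounds alone.

Two ureas sharing the same core have been measured. Compound 1 `Cc1ccc(NC(=O)Nc2ccc(Oc3ccc(-c4nccs4)cc3)cc2)cc1` carries a 4-methylphenyl group on one urea nitrogen, and in a functional assay on MDA-MB-231 cells (Homo sapiens) for inhibition, read by MTT assay and WST assay, with a stated time of 72 h, tested at 10 uM (a higher number here means more inhibition of growth at the concentration tested, a lower number less inhibition of growth), compound 1 gives 22.8%. Compound 2 `CC(=O)Oc1sccc1NC(=O)Nc1ccc(Oc2ccc(-c3nccs3)cc2)cc1` instead carries a 2-acetoxythiophen-3-yl group on that nitrogen, and in this assay compound 2 gives 11%. This one change produced a number 11.8 percentage points lower from compound 1 to compound 2 (beyond the scatter). Going by the values given here, on the numbers so far, compound 2 therefore stands lowest of the two, with compound 1 the nearest and higher by a margin beyond the scatter.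

Compound 3 `CC(=O)Oc1sccc1NC(=O)Nc1ccc(Oc2ccc(-c3ncc[nH]3)cc2)cc1` keeps everything of compound 2 except the small aromatic ring at the far end of the molecule: 1H-imidazol-2-yl in place of 1,3-thiazol-2-yl on an aromatic carbon. Among the compounds with values here, no measured step touches this part of the core; the only known step concerns the group on the urea nitrogen, so it gives no guide to the size or direction of this change. Without a comparable step, no movement beyond the scatter is expected in this assay, and the estimate for compound 3 is a number 2 percentage points higher from compound 2 to compound 3 (within the scatter). Compound 3 is thus expected to give about 13%, within a range from 0% to 30%.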

Compound 3, percent growth inhibition at one concentration: -1.46%
Compound 3: the middle estimate sits 14.5 percentage points above what was measured; the measured number lies below the stated range.
By their numbers in this assay, from the lowest: compound 3; then compound 2; then compound 1.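

The small ring at the far end of the molecule can also move the number: with the 2-acetoxythiophen-3-yl group kept on the urea nitrogen, 1H-imidazol-2-yl in place of 1,3-thiazol-2-yl on an aromatic carbon gives a number 12.5 percentage points lower from compound 2 to compound 3 (beyond the scatter) in this assay. The two rings each hold 5 heavy atoms and each form one five-membered aromatic ring with 2 hetero atoms, so a swap that keeps the ring size, with a nitrogen carrying a hydrogen where the sulfur stood, is enough for a step beyond the scatter. No measurement at hand says why this swap lowers the number.

As far as these compounds go, this step is known only with the 2-acetoxythiophen-3-yl group in place, so it remains open whether the same swap would lower the number with the 4-methylphenyl group of compound 1 on the urea nitrogen. The compounds shown also leave open how this position would read with a six-membered ring such as pyridin-2-yl, or with a small group such as an amine or a carboxylic acid instead of a ring.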